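Methyl in place of hydrogen: compound 3 to compound 4

This account rests on a few compounds, and the source may have more. Where it says the series, first, only, none or still open, it means among the compounds named here.

Three compounds share one core and differ only in the five-membered aromatic ring attached to it. In a functional assay with Alpha-1A adrenergic receptor (Homo sapiens) as the target, read by calcium flux (on this read-out higher numbers stand for larger maximal responses and lower numbers for smaller maximal responses), compound 1 `c1c[nH]c(-c2ccccc2OCC2=NCCN2)c1` gives 99%, compound 2 `c1ccc(-c2cc[nH]n2)c(OCC2=NCCN2)c1` gives 119% and compound 3 `c1ccc(-c2ccns2)c(OCC2=NCCN2)c1` gives 99%. Compound 3 stands level with compound 1, the two together being the lowest of the three numbers; the nearest to it is compound 1, with no change at the digits printed from compound 1 to compound 3 (within the scatter), and the furthest is compound 2, with a number 20 percentage points lower from compound 2 to compound 3 (beyond the scatter). Among the measured compounds shown here, the only steps beyond the scatter are a number 20 percentage points higher from compound 1 to compound 2 (beyond the scatter) and a number 20 percentage points lower from compound 2 to compound 3 (beyond the scatter).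

Compound 4 `Cc1cnsc1-c1ccccc1OCC1=NCCN1` differs from compound 3 by methyl in place of hydrogen on an aromatic carbon. For the measured compounds named here, all three measured steps exchange one five-membered aromatic ring for another; none of them adds a methyl group to a ring that is otherwise kept, so no measured step bears directly on this change. What the measured compounds do show is that all three numbers lie within a narrow band. With no direct guide for the methyl, the expected step is a number 1 percentage points higher from compound 3 to compound 4 (within the scatter), that is, none beyond the scatter. Compound 4 is therefore estimated at 100%, with a range of 80% to 120%.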

Compound 4, largest response reached (reported as maximum), in percent of the reference or control that the assay uses: 104%
Beside the measured number, compound 4's estimate is 4 percentage points below it; measured number inside the range.
By their numbers in this assay, from the lowest: compounds 1, 3 and 4 (each within the scatter of the next); then compound 2.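

In this assay the methyl on the aromatic carbon next to the ring atom that bears a large group, two ring bonds from the ring nitrogen and two ring bonds from the ring sulfur, gives a number 5 percentage points higher from compound 3 to compound 4 (within the scatter) and so leaves the maximal response of the 1,2-thiazol-5-yl series in place. Among the compounds shown here, the 4-methyl-1,2-thiazol-5-yl ring also shows a number 5 percentage points higher from compound 1 to compound 4 (within the scatter) against the 1H-pyrrol-2-yl ring, while a number 15 percentage points lower from compound 2 to compound 4 (beyond the scatter) shows that the methyl does not close the gap to the 1H-pyrazol-3-yl ring, and compound 2 remains the only compound apart from the others. No measurement at hand accounts for any of these steps.

From the compounds shown here alone, whether this carbon accepts more than a methyl remains open, since an ethyl, a methoxy, an aminomethyl or a carboxylic acid there could give a different maximal response. Also open, going by these compounds, is whether a methyl on the 1H-pyrazol-3-yl ring of compound 2 would leave its response in place as it does on the 1,2-thiazol-5-yl ring, and the maximal response alone gives no view of potency.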